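Extending the propyl chain of compound 3 with a benzyl carbamate

The compounds below may be only part of what the source reports. "The series", "measured", "known", "first", "only" and "open" are said of these compounds alone.

Compound 1 `CCCn1c(NC(=O)c2cc(C)nn2CC)nc2cccc(OC)c21` reaches only the limit > 100000 nM in an assay for activation of interferon regulatory factor 3 (Homo sapiens), read by a luciferase reporter, with a stated time of 20 h; on this read-out lower numbers stand for an effect already at smaller amounts and higher numbers for an effect only at larger amounts of compound.
Compound 2 `CCCn1c(NC(=O)c2cc3ccccc3n2C)nc2cc(C(N)=O)cc(OC)c21` reaches only the limit > 100000 nM in this assay.
Compound 3 `CCCn1c(NC(=O)CCc2ccccc2)nc2cc(C(N)=O)cc(OC)c21` reaches only the limit > 100000 nM in this assay.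

All three measured values are limits of the assay rather than numbers, and so compound 3 stands nowhere in particular on the scale: it sits, like the other two, at the limit of > 100000 nM in this assay, at which 3 of the 3 values shown sit. Within the data shown here, the one step between measured compounds that differ in a single place, a step that the two limits leave unreadable from compound 2 to compound 3, is therefore unreadable, and no measured step tells how the series responds to a change.

Compound 4 `COc1cc(C(N)=O)cc2nc(NC(=O)CCc3ccccc3)n(CCCNC(=O)OCc3ccccc3)c12` differs from compound 3 by (benzyloxycarbonyl)amino in place of hydrogen on a saturated chain carbon, three bonds along the chain from an aromatic nitrogen. The change adds a (benzyloxycarbonyl)amino group three bonds along the saturated chain from the aromatic nitrogen, while the phenethyl amide of compound 3 is kept.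

With no readable step to lean on, the only expectation that the data support is that compound 4 behaves like the compounds that share its core, and the step of a number no higher from compound 3 to compound 4 (the limit leaves the size open) is estimated as none beyond the scatter, with the measurement most likely ending at a limit again. Compound 4 is expected to give about 100000 nM, within 10000 nM to 300000 nM.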

Compound 4, half-maximal effective concentration: > 100000 nM
Compound 4 gave a limit, no number; the forecaster's own chance of this, stated with the estimate: 75%; the middle value sits exactly at the limit.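

Compound 3 and compound 4 both end at a limit rather than a number, so no step can be read between them: the limit of > 100000 nM in this assay, at which 4 of the 4 values shown sit. The compounds shown leave open which change to the shared core, if any, would give a measured number in this assay and what the (benzyloxycarbonyl)amino group would then contribute.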